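The source may hold more compounds than are shown below. What is called first, only, known or untested is meant among the compounds shown, and "the series" means these compounds.

Compound 1 `CC(=O)OCCc1c(C)[nH]c(=O)[nH]c1=O`: > 100000 nM.
Compound 2 `CC(=O)OCCc1c(C)nc(Cl)nc1Cl`: > 100000 nM.
Compound 3 `Cc1nc(Cl)nc(Cl)c1CCCl`: 400 nM.

In a functional assay on SW-620 cells (Homo sapiens) for antiproliferative activity, read by MTT assay, with a stated time of 24 h (on this read-out higher numbers stand for weaker inhibition and lower numbers for stronger inhibition), compound 1 returns only a limit, not a number. Compound 2 likewise stops at the limit of > 100000 nM in this assay, at which 2 of the 3 values shown sit. Compound 3 differs from compound 2 by chloro in place of acetoxy on a saturated chain carbon, two bonds along the chain from an aromatic carbon, and that change gave an at least 250-fold lower number from compound 2 to compound 3 (2.39 log units; beyond the scatter). Compound 4 `Cc1[nH]c(=O)[nH]c(=O)c1CCCl`, not yet measured, differs from compound 1 by chloro in place of acetoxy on a saturated chain carbon, two bonds along the chain from an aromatic carbon, the same change at the same place. How the core of compound 1 differs from that of compound 2 is not broken down here. Since compound 2 sits at a limit, the measured step is only a floor for the size of this change. A somewhat smaller step is expected on the core of compound 1, and compound 4 is expected to show an at least 10-fold lower number from compound 1 to compound 4 (1.00 log units; beyond the scatter). Compound 4 is thus estimated at 10000 nM, within a span from 1500 nM to 60000 nM.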

Compound 4, half-maximal inhibitory concentration: > 100000 nM
Compound 4 gave a limit, no number; the forecaster's own chance of this, stated with the estimate: 30%; middle value at least 10-fold (1.00 log units) away from the limit.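

Compound 1 and compound 4 both end at a limit in this assay, so the step between them cannot be read: the limit of > 100000 nM in this assay, at which 3 of the 4 values shown sit.

The compounds shown leave open how large the change of acetoxy to chloro is on the core of compound 1.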